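Swapping chloro for methoxy in a well-tolerated compound

The compounds below may be only part of what the source reports. "The series", "measured", "known", "first", "only" and "open" are said of these compounds alone.

In an ADME assay on HEL cells (Homo sapiens) for inhibition, read by cell counting (a lower number here means that less compound is tolerated, a higher number that more compound is tolerated), compound 1 (`Nc1nc(O)c2ncn(CSC(CO)CO)c2n1`) gives > 100000 nM as its result, which is a limit of the assay and not a number. Compound 2 (`Nc1nc(Cl)c2ncn(CCC(CO)CO)c2n1`) gives > 100000 nM as its result, and this too is a limit. Compound 2 therefore has no exact value and stands with compound 1 at the limit of > 100000 nM in this assay, at which 2 of the 2 values shown sit, and no other measured value beside them.

Compound 3 (`COc1nc(N)nc2c1ncn2CCC(CO)CO`) has methoxy in place of chloro on an aromatic carbon. Going by the values given here, no measured pair shows what this swap does. On the strength of the limit of > 100000 nM in this assay, at which 2 of the 2 values shown sit, alone, no shift beyond the usual scatter is expected in this assay, in either direction. What is expected is a number no higher from compound 2 to compound 3 (the limit leaves the size open) and so a small step at most. Compound 3 is estimated at 100000 nM (range 40000 nM to 250000 nM) and may well be reported as a limit too.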

Compound 3, half-maximal cytotoxic concentration: > 100000 nM
Compound 3: no number, only a limit; the forecaster's own chance of this, stated with the estimate: 80%; the middle value sits exactly at the limit.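

Going by these compounds alone, compound 2 and compound 3 both give only a limit of the assay in this assay, so no step between them can be read. The compounds shown leave open where their exact values lie, and so whether methoxy in place of chloro on an aromatic carbon changes the result at all.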